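Compound 1 and its 2,6-difluorophenyl analogue, compound 4

The source may hold more compounds than are shown below. What is called first, only, known or untested is meant among the compounds shown, and "the series" means these compounds.

Among the measured compounds shown here, in a functional assay on A-375 cells (Homo sapiens) for inhibition, read by CCK-8 assay, with a stated time of 72 h (a lower number here means a stronger inhibitor, a higher number a weaker inhibitor), compound 1 `Nc1ccccc1NC(=O)c1ccc(CNC(=O)c2n[nH]cc2NC(=O)c2ccccc2)cc1` gives 1590 nM, the lowest number of the three measured so far. Compound 2 `O=C(NO)c1ccc(CNC(=O)c2n[nH]cc2NC(=O)c2c(Cl)cccc2Cl)cc1` gives 5050 nM and compound 3 `O=C(NO)c1ccc(CNC(=O)c2n[nH]cc2NC(=O)c2ccccc2Cl)cc1` gives 6420 nM. Both lie beyond the scatter from compound 1.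

Compound 4 `Nc1ccccc1NC(=O)c1ccc(CNC(=O)c2n[nH]cc2NC(=O)c2c(F)cccc2F)cc1` keeps the core of compound 1 and changes one group: 2,6-difluorophenyl in place of phenyl on a carbonyl carbon. This places 2,6-difluorophenyl in place of phenyl on a carbonyl carbon.

For the measured compounds named here, only one measured step bears on this change: a 1.3-fold higher number from compound 2 to compound 3 (0.10 log units; within the scatter), with hydrogen in place of chloro on an aromatic carbon. It is a small step, within the scatter, but it is indirect evidence. Going by the values given here, compound 2 and compound 3 also differ from compound 1 elsewhere in the structure, and no measured pair tests fluoro groups or compares a halogenated group directly with phenyl.

On the strength of that single step, no change beyond the scatter is expected in this assay, and the data support no direction. The expected step is a 1.1-fold higher number from compound 1 to compound 4 (0.05 log units; within the scatter). For compound 4 the estimated value is 1800 nM, with an expected range of 700 nM to 4500 nM.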

Compound 4, half-maximal inhibitory concentration: 1700 nM
The estimate for compound 4 lay 1.1-fold (0.02 log units) above the measured number, and the stated range covers the measured number.
By their numbers in this assay, from the lowest: compounds 1 and 4 (each within the scatter of the next); then compounds 2 and 3 (each within the scatter of the next).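

In this assay, among the compounds shown here, the step of a 1.1-fold higher number from compound 1 to compound 4 (0.03 log units; within the scatter) gives the first direct reading at this place, on a carbonyl carbon whose other neighbour is an amide-type nitrogen, with the rest of the core of compound 1 unchanged. The earlier step of a 1.3-fold higher number from compound 2 to compound 3 (0.10 log units; within the scatter) concerned a chloro group on an aromatic carbon, in compounds that differ from compound 1 elsewhere, whereas this pair shows that phenyl and 2,6-difluorophenyl cannot be told apart in this read-out on the core of compound 1. Nothing at hand explains why the number stays within the scatter.

The compounds shown leave open whether a group of a different kind at this carbonyl carbon, such as cyclohexyl, pyridyl or a phenyl ring carrying a methoxy group or an amine, would move the number beyond the scatter. For the compounds shown here, they also leave open whether 2,6-difluorophenyl gives the same result on the core of compound 2 and compound 3, where the only measured change at this group is the loss of a chloro group.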